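A few compounds are considered here, and "the series" means these few. Any claim that something is new, unique, unknown or untested is made for them only; others in the source may bear on it.

Measured so far:
compound 1, `COc1cc(-c2nnc(SCC(=O)c3ccc(C)cc3)n2N)cc(OC)c1OC`: 2940 nM
compound 2, `COc1cc(-c2nnc(SCC(=O)c3ccc(F)cc3)n2N)cc(OC)c1OC`: 20900 nM

Compound 2 gives the highest number of the two in a functional assay on HeLa cells (Homo sapiens) for antiproliferative activity, read by MTT assay, with a stated time of 48 h; a lower number here means a stronger inhibitor, a higher number a weaker inhibitor; its nearest neighbour is compound 1, separated from it by the step of a 7.1-fold higher number from compound 1 to compound 2 (0.85 log units; beyond the scatter), the two differing by fluoro in place of methyl on an aromatic carbon. Compound 3, `COc1cc(-c2nnc(SCC(=O)c3ccccc3F)n2N)cc(OC)c1OC`, has not yet been measured in this assay. It differs from compound 2 by 2-fluorophenyl in place of 4-fluorophenyl on a carbonyl carbon. Among the measured compounds shown here, no measured step bears on this change directly: the single step in hand, a 7.1-fold higher number from compound 1 to compound 2 (0.85 log units; beyond the scatter), exchanges one group for another on the aromatic carbon, whereas the move to compound 3 keeps the same atoms and joins them differently. The series thus offers no direction for this change, and for compound 3 the expected step is one near the scatter, a 1.4-fold lower number from compound 2 to compound 3 (0.14 log units; within the scatter), carrying wide uncertainty. Compound 3 is estimated at 15000 nM, within the range 5000 nM to 50000 nM.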

Compound 3, half-maximal inhibitory concentration: 80100 nM
Compound 3: the middle estimate sits 5.3-fold (0.73 log units) below what was measured; measured number above the stated range.
By their numbers in this assay, from the lowest: compound 1; then compound 2; then compound 3.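

In this assay, the fluorine's place on the ring is not neutral: with the same atoms joined differently, 2-fluorophenyl in place of 4-fluorophenyl on the carbonyl carbon gives a 3.8-fold higher number from compound 2 to compound 3 (0.58 log units; beyond the scatter), so the place of the substituent counts here as well as its identity. Against 4-methylphenyl the same group gives a 27-fold higher number from compound 1 to compound 3 (1.44 log units; beyond the scatter), which makes this the widest step in the set and puts 4-methylphenyl at the lowest number and 2-fluorophenyl at the highest among the three compounds, all with the shared core unchanged. No measurement at hand explains why these changes on the carbonyl carbon move the number as they do.

Still open, as far as these compounds go, is whether the higher number with 2-fluorophenyl belongs to fluorine or would also appear with 2-methylphenyl, since methyl occurs here only as 4-methylphenyl. Also open, from the compounds shown here alone, is where unsubstituted phenyl, 4-chlorophenyl or 4-methoxyphenyl would fall relative to compound 1 and compound 2, which would show whether 4-methylphenyl stands out or fluorine in either place carries a penalty.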